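A Small Addition to Compound 2

A few compounds are considered here, and "the series" means these few. Any claim that something is new, unique, unknown or untested is made for them only; others in the source may bear on it.

Among the compounds with values here, compound 2 `O=C(O)c1cccc(NC(=O)c2cccc(-c3ccccc3)c2)c1` gives 25 nM in an assay on isolated protein for agonist activity at Bile acid receptor (Homo sapiens), read by TR-FRET, with a stated time of 3 h, in the absence of a further agent (a higher number here means that more compound is needed for the effect, a lower number that less compound is needed), the lowest of the two numbers measured so far; the nearest is compound 1 `Cc1ccc(COc2cccc(C(=O)Nc3cccc(C(=O)O)c3)c2)cc1`, which gives 1430 nM. Compound 3 `Cc1ccccc1-c1cccc(C(=O)Nc2cccc(C(=O)O)c2)c1` differs from compound 2 by methyl in place of hydrogen on an aromatic carbon, on an aromatic carbon of a six-membered aromatic ring of carbon only, ortho to a large group. Within the data shown here, the one measured step, a 57-fold lower number from compound 1 to compound 2 (1.76 log units; beyond the scatter), swapped a whole group and says little about a single methyl. Among the measured compounds shown here, no measured step bears directly on this change, so the expected step of a 1.2-fold higher number from compound 2 to compound 3 (0.08 log units; within the scatter) is none beyond the scatter. Compound 3 is therefore estimated at 30 nM, with a range from 8 nM to 120 nM.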

Compound 3, half-maximal effective concentration: 68 nM
Compound 3: middle estimate off by 2.3-fold (0.36 log units), on the low side, and the stated range covers the measured number.
By their numbers in this assay, from the lowest: compound 2; then compound 3; then compound 1.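

A single methyl, ortho to a large group, is enough to shift the number in this assay: the change gives a 2.7-fold higher number from compound 2 to compound 3 (0.43 log units; beyond the scatter), so even this small addition to the phenyl is not neutral here. The 2-methylphenyl group still keeps much of the advantage over (4-methylbenzyl)oxy, giving a 21-fold lower number from compound 1 to compound 3 (1.32 log units; beyond the scatter). Nothing available explains why the methyl has this effect. Still open, on these data alone, is whether a methoxy group, a chlorine atom or an amine at this place would act as methyl does. Also open, as far as these compounds go, is how methyl would act on another carbon of this ring.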